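The source may hold more compounds than are shown below. What is called first, only, known or untested is meant among the compounds shown, and "the series" means these compounds.

Measured compounds:
- Compound 1 `CC(C)(C)c1ccc(OCC(=O)O)c(C2(c3ccccc3)C(=O)Nc3ccccc32)c1`: in a functional assay on cells (Homo sapiens) for antiproliferative activity, read by sulforhodamine B assay, with a stated time of 5 days (on this read-out lower numbers stand for stronger inhibition and higher numbers for weaker inhibition), compound 1 gives > 20000 nM, which is a limit of the assay and not a number.
- Compound 2 `CN(C)c1ccc(C2(c3cc(C(C)(C)C)ccc3O)C(=O)Nc3ccccc32)cc1`: in this assay compound 2 gives 2300 nM.

Going by the values given here, compound 2 therefore holds the only number so far in this assay; the one other value shown is a limit, as noted in the limit of > 20000 nM in this assay, at which 1 of the 2 values shown sits. Among the compounds with values here, no step between two measured compounds is available, since compound 1 and compound 2 differ in more than one place, so their values are simply set side by side without a computed difference.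

The step to be followed is from compound 2 to compound 3 `CC(C)(C)c1ccc(O)c(C2(c3cccnc3)C(=O)Nc3ccccc32)c1`. The change is pyridin-3-yl in place of 4-(dimethylamino)phenyl on a saturated ring carbon. Nothing measured in this series speaks for or against that exchange, so the expectation rests on compound 2 alone.

Compound 3 is expected to come out at 5000 nM, with a range from 1500 nM to 20000 nM. That estimate means a step of a 2.2-fold higher number from compound 2 to compound 3 (0.34 log units; beyond the scatter) toward weaker inhibition, with a real chance that only a limit is reported.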

Compound 3, half-maximal inhibitory concentration: 6400 nM
Beside the measured number, compound 3's estimate is 1.3-fold (0.11 log units) below it; the measured number falls inside the stated range.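

In this assay, going by these compounds alone, the exchange of 4-(dimethylamino)phenyl for pyridin-3-yl on the saturated ring carbon gives the first readable step, a 2.8-fold higher number from compound 2 to compound 3 (0.44 log units; beyond the scatter), and it runs toward weaker inhibition. The position therefore responds to a change of aromatic group, even though the two groups match in the counts of hydrogen-bond donors and acceptors and neither carries a net charge; they differ in heavy atoms, and in where the nitrogen sits, in the ring of pyridin-3-yl and outside the ring in 4-(dimethylamino)phenyl. Within the data shown here, compound 3 also still gives a number rather than a limit, yet nothing measured so far accounts for the size or direction of this step.

Open, on these data alone, is whether the step comes from losing the dimethylamino group or from placing a nitrogen in the ring, a question that a comparison on this same carbon with a 4-methoxyphenyl or a pyridin-4-yl group would help to separate. Also open, as far as these compounds go, is how a saturated amine such as piperidin-4-yl would behave at this position, with the free hydroxyl kept on the tert-butyl-bearing ring.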